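Compound 4: Pyridin-3-yl in Place of 2-Chlorophenyl

A few compounds are considered here, and "the series" means these few. Any claim that something is new, unique, unknown or untested is made for them only; others in the source may bear on it.

Three compounds share one core: compound 1 `CC1=C(/C=C/C(=O)/C=C/c2ccc(Br)cc2)C(C)(C)CCC1`, compound 2 `CC1=C(/C=C/C(=O)/C=C/c2ccc(F)cc2)C(C)(C)CCC1` and compound 3 `CC1=C(/C=C/C(=O)/C=C/c2ccccc2Cl)C(C)(C)CCC1`. In a functional assay on IMR-32 cells (Homo sapiens) for cytotoxicity, read by sulforhodamine B assay, with a stated time of 48 h (a lower number here means a stronger inhibitor, a higher number a weaker inhibitor), compound 1 gives 10400 nM, compound 2 gives 7400 nM and compound 3 gives 13700 nM. Compound 3 carries the highest of the three numbers, yet the steps to it are small, a 1.3-fold higher number from compound 1 to compound 3 (0.12 log units; within the scatter) and a 1.9-fold higher number from compound 2 to compound 3 (0.27 log units; within the scatter), as is a 1.4-fold lower number from compound 1 to compound 2 (0.15 log units; within the scatter). Compound 4 `CC1=C(/C=C/C(=O)/C=C/c2cccnc2)C(C)(C)CCC1` differs from compound 3 by pyridin-3-yl in place of 2-chlorophenyl on a double-bonded chain carbon bound to a double-bonded chain carbon. Among the compounds with values here, the measured steps exchange only one halogen-bearing ring for another and all lie within the scatter; none brings in a ring with a hetero atom, so they give no footing for a shift. Compound 4 is therefore expected to move little, a 1.1-fold lower number from compound 3 to compound 4 (0.02 log units; within the scatter). The estimate for compound 4 in this assay is 13000 nM, between 5000 nM and 35000 nM.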

Compound 4, half-maximal inhibitory concentration: 25300 nM
The estimate for compound 4 lay 1.9-fold (0.29 log units) below the measured number, and the stated range covers the measured number.
By their numbers in this assay, from the lowest: compounds 2, 1, 3 and 4 (each within the scatter of the next, the first and the last beyond it).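

In this assay, within the data shown here, pyridin-3-yl is the only ring with a hetero atom on the double-bonded chain carbon, and a 2.4-fold higher number from compound 1 to compound 4 (0.39 log units; beyond the scatter) and a 3.4-fold higher number from compound 2 to compound 4 (0.53 log units; beyond the scatter) are the only steps here to pass beyond the scatter, while a 1.8-fold higher number from compound 3 to compound 4 (0.27 log units; within the scatter) does not. This position therefore tolerates a change that moves the number measurably, though only modestly and, among these compounds, only upward. No measured evidence bears on the reason for this shift. Going by these compounds, whether a pyridin-4-yl ring, or a phenyl ring bearing an amine, would raise or lower the number stays open.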